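This account rests on a few compounds, and the source may have more. Where it says the series, first, only, none or still open, it means among the compounds named here.

In an ADME assay on CCRF-CEM cells (Homo sapiens) for cytotoxicity, read by cell counting (on this read-out higher numbers stand for lower toxicity in this test and lower numbers for higher toxicity in this test), the measured compounds gave these numbers:
compound 1, `Cc1cc(C)cc(S(=O)(=O)c2c(C(=O)NCc3ccccc3)[nH]c3ccc(Cl)c(F)c23)c1`, 15000 nM
compound 2, `Cc1cc(C)cc(S(=O)(=O)c2c(C(=O)NCN3CCCCC3)[nH]c3ccc(Br)cc23)c1`, 10000 nM
compound 3, `Cc1cc(C)cc(S(=O)(=O)c2c(C(=O)NCc3ccccc3)[nH]c3ccc([N+](=O)[O-])cc23)c1`, 8000 nM

Compound 2 holds the second highest of the three numbers in this assay; its distance to compound 3, the nearest, and to compound 1, the furthest, both lie within the usual scatter, so the three compounds cannot be told apart on these data.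

Compound 4 is `Cc1cc(C)cc(S(=O)(=O)c2c(C(=O)NCN3CCCC3)[nH]c3ccc(Br)cc23)c1`. It differs from compound 2 by pyrrolidin-1-yl in place of piperidin-1-yl on a saturated chain carbon bound to an amide-type nitrogen. Within the data shown here, no measured pair shows this change, so nothing is known of its effect. Among the measured compounds shown here, the expected step of no change at the digits printed from compound 2 to compound 4 (within the scatter) is none beyond the scatter, since the change is only one ring carbon. Compound 4 is therefore expected to give about 10000 nM in this assay, with a range from 4000 nM to 25000 nM.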

Compound 4, half-maximal cytotoxic concentration: 9600 nM
Beside the measured number, compound 4's estimate is 1.0-fold (0.02 log units) above it, and the stated range covers the measured number.
By their numbers in this assay, from the lowest: compounds 3, 4, 2 and 1 (each within the scatter of the next).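

Swapping piperidin-1-yl for pyrrolidin-1-yl on a saturated chain carbon bound to an amide-type nitrogen gives, in this assay, a 1.0-fold lower number from compound 2 to compound 4 (0.02 log units; within the scatter), the only pair shown that differs at this place alone. At this place, then, the six-membered non-aromatic ring can give way to the five-membered one with no change beyond the scatter. Nothing measured here bears on why the two compounds read alike.

The compounds shown leave open whether morpholin-4-yl or an open-chain diethylamino group on the same carbon would read the same in this assay.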